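This account rests on a few compounds, and the source may have more. Where it says the series, first, only, none or still open, it means among the compounds named here.

Working notes on the series.

Compound 1 `CCOC(=O)C(=O)CC(=O)/C=C/c1cn(-c2ccc(O)cc2)c2ccccc12` carries a 4-hydroxyphenyl on the aromatic nitrogen of the shared core. In an assay on isolated protein for inhibition of DNA nucleotidylexotransferase (Homo sapiens), read by scintillation counting, with a stated time of 10 min (a higher number here means a weaker inhibitor, a lower number a stronger inhibitor), compound 1 gives > 40 uM, which is a limit of the assay and not a number. Compound 2 `CCOC(=O)C(=O)CC(=O)/C=C/c1cn(Cc2ccccc2)c2ccccc12` has a benzyl on that nitrogen instead. In this assay compound 2 gives > 40 uM, again a limit and not a number. The step that the two limits leave unreadable from compound 1 to compound 2 is therefore not readable in size or direction; both values sit at the limit of > 40 uM in this assay, at which 2 of the 2 values shown sit. Compound 2 thus stands at the limit, with no number to place it against any other compound.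

The next compound, compound 3 `CCOC(=O)C(=O)CC(=O)/C=C/c1cn(Cc2ccc(Cl)cc2)c2ccccc12`, differs from compound 2 by chloro in place of hydrogen on an aromatic carbon. Among the measured compounds shown here, no measured step reads on this change: the one step in the set is unreadable because both of its values sit at the limit of > 40 uM in this assay, at which 2 of the 2 values shown sit. The expected outcome for compound 3 in this assay is that it again sits at the limit, with an estimated step that the limit leaves unreadable from compound 2 to compound 3 that is not readable beyond the scatter. The estimate for compound 3 is 60 uM, with a range from 15 uM to 250 uM.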

Compound 3, concentration for 50% inhibition: 40 uM
Estimate against measurement, compound 3: 1.5-fold (0.18 log units) above; the range from low to high includes it.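

In this assay, among the compounds shown here, compound 3 gives 40 uM, the first value that is a number and not a limit. Chloro in place of hydrogen, para to a large group on the benzyl, reads as a number no higher from compound 2 to compound 3 (the limit leaves the size open), and the change on the aromatic nitrogen from 4-hydroxyphenyl to 4-chlorobenzyl reads as a number no higher from compound 1 to compound 3 (the limit leaves the size open). Neither step has a readable size, so the series shows only that compound 3 gives a number where the other two compounds stop, and the comparison ends at their shared value: the limit of > 40 uM in this assay, at which 2 of the 3 values shown sit.

Still open, on these data alone, is whether the chloro itself matters at this place, or whether fluoro, bromo, methoxy or an amine there would give values clearly apart from compound 3. Also open, as far as these compounds go, is how a longer chain between the aromatic nitrogen and the phenyl ring would read, and how a free carboxylic acid in place of the ethyl ester of the shared core would read.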